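The source may hold more compounds than are shown below. What is called first, only, known or untested is meant among the compounds shown, and "the series" means these compounds.

Measured so far in a functional assay on CCRF-CEM cells (Homo sapiens) for cytotoxicity, read by MTT assay, with a stated time of 72 h; a lower number here means that less compound is tolerated, a higher number that more compound is tolerated:
Compound 1 `CCCCC[Se]c1nc(NCc2ccc(SC)cc2)c2ccccc2n1` gives > 100000 nM, a limit of this assay.
Compound 2 `CCCCC[Se]c1nc([Se]CCCCC)c2ccccc2n1` gives > 100000 nM, a limit of this assay.
Compound 3 `CCCCC[Se]c1nc(NCc2ccccc2)c2ccccc2n1` gives > 100000 nM, a limit of this assay.

Compound 3 therefore stands only at a limit, as do all three values shown (the limit of > 100000 nM in this assay, at which 3 of the 3 values shown sit). Compound 4 `CSc1nc(NCc2ccccc2)c2ccccc2n1` differs from compound 3 by a group of 2 heavy atoms (1 carbon, 1 sulfur; no ring) in place of a group of 6 heavy atoms (5 carbon, 1 selenium; no ring), on an aromatic carbon. The two measured steps that end at compound 3, a step that the two limits leave unreadable from compound 1 to compound 3 and a step that the two limits leave unreadable from compound 2 to compound 3, are both unreadable, so no size or direction can be read from them, and neither touches the group that leaves here. The expectation for compound 4 is a further limit, with a number no higher from compound 3 to compound 4 (the limit leaves the size open) expected to be flat. Compound 4 is estimated at 100000 nM, within 30000 nM to 300000 nM.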

Compound 4, concentration lethal to 50% of the cells: > 100000 nM
Compound 4 ended at the assay's limit; the forecaster's own chance of this, stated with the estimate: 75%; the middle value lies on the limit itself.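

No step can be read between compound 3 and compound 4, as each stands only at a limit: the limit of > 100000 nM in this assay, at which 4 of the 4 values shown sit.

The compounds shown leave open what size of effect any change on the shared core has in this assay.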